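A few compounds are considered here, and "the series" means these few. Any claim that something is new, unique, unknown or untested is made for them only; others in the source may bear on it.

Measured in an ADME assay on RAW264.7 cells (Mus musculus) for cytotoxicity, read by MTT assay, with a stated time of 24 h; on this read-out higher numbers stand for lower toxicity in this test and lower numbers for higher toxicity in this test:
compound 1 `Cc1ccc(C2=NN(C3=NC(=O)CS3)C(c3ccccc3)C2)cc1C` gives > 450000 nM, which is a limit of the assay and not a number.
compound 2 `COc1ccc(C2CC(c3ccc(C)c(C)c3)=NN2C2=NC(=O)CS2)cc1` gives 387000 nM.
compound 3 `Cc1cccc(C2CC(c3ccc(C)c(C)c3)=NN2C2=NC(=O)CS2)c1` gives 237000 nM.

Compound 3 holds the lowest of the two numbers; its nearest neighbour is compound 2, and the step of a 1.6-fold lower number from compound 2 to compound 3 (0.21 log units; within the scatter) lies within the scatter. Compound 1 contributes only a limit (the limit of > 450000 nM in this assay, at which 1 of the 3 values shown sits). Compound 4 `Cc1ccc(C2=NN(C3=NC(=O)CS3)C(c3ccccc3Cl)C2)cc1C` remains to be measured and differs from compound 3 in 2-chlorophenyl in place of 3-methylphenyl on a saturated ring carbon. The step that bears on this change is the exchange of the aryl group on the saturated ring carbon, a 1.6-fold lower number from compound 2 to compound 3 (0.21 log units; within the scatter), within the scatter; the steps of an at least 1.1-fold lower number from compound 1 to compound 2 (0.06 log units; that floor lies within the scatter) and an at least 1.8-fold lower number from compound 1 to compound 3 (0.27 log units; that floor lies within the scatter) have floors within the scatter too. In this assay no shift beyond the scatter is therefore expected, the estimated step being a 1.1-fold higher number from compound 3 to compound 4 (0.04 log units; within the scatter). Compound 4 is estimated at 260000 nM, within 120000 nM to 450000 nM.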

Compound 4, half-maximal cytotoxic concentration: 227000 nM
For compound 4 the middle estimate is 1.1-fold (0.06 log units) above the measured one, and the stated range covers the measured number.
By their numbers in this assay, from the lowest: compounds 4, 3 and 2 (each within the scatter of the next). At a limit, above all of these: compound 1.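

In this assay, 2-chlorophenyl on the saturated ring carbon next to the ring nitrogen gives a 1.0-fold lower number from compound 3 to compound 4 (0.02 log units; within the scatter), and against 4-methoxyphenyl it gives a 1.7-fold lower number from compound 2 to compound 4 (0.23 log units; within the scatter). A chloro-substituted aryl group at this position thus joins the methyl- and methoxy-substituted ones with no shift beyond the scatter. Against the unsubstituted phenyl of compound 1 the step is only a floor, an at least 1.9-fold lower number from compound 1 to compound 4 (0.29 log units; that floor lies within the scatter), since the value of compound 1 is a limit of the assay and not a number: the limit of > 450000 nM in this assay, at which 1 of the 4 values shown sits.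

On these data alone, whether an amine or a carboxylic acid on the aryl group at this carbon would shift the number beyond the scatter stays open. So does the effect of any exchange of the 3,4-dimethylphenyl group.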